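Swapping Methyl for Chloro on a Shared Core

The source may hold more compounds than are shown below. What is called first, only, known or untested is meant among the compounds shown, and "the series" means these compounds.

Measured compounds:
compound 1, `O=C1CN(/N=C2\CCOc3ccc(Cl)cc32)C(=O)N1CCCCN1CCCCC1`: 61000 nM
compound 2, `Cc1ccc2c(c1)/C(=N/N1CC(=O)N(CCCCN3CCCCC3)C1=O)CCO2`: 18900 nM
compound 3, `Cc1ccc2c(c1)/C(=N/N1CC(=O)N(CCCN3CCN(C)CC3)C1=O)CCO2`: 304 nM

All three were tested in an assay on cells (Ventricular myocyte) for inhibition of potassium voltage-gated channel subfamily KQT member 1 (Cavia porcellus), read by patch clamp; on this read-out higher numbers stand for weaker inhibition and lower numbers for stronger inhibition. Compound 1 gives 61000 nM, compound 2 gives 18900 nM, and compound 3 gives 304 nM, the lowest of the three numbers, with both steps to the others beyond the scatter.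

Two single changes connect them. From compound 2 to compound 1 the change is chloro in place of methyl on an aromatic carbon, and it made a step of a 3.2-fold higher number from compound 2 to compound 1 (0.51 log units; beyond the scatter). From compound 2 to compound 3 the change is 4-methylpiperazin-1-yl in place of (piperidin-1-yl)methyl on a saturated chain carbon, three bonds along the chain from an amide-type nitrogen in a ring, and it made a much larger step of a 62-fold lower number from compound 2 to compound 3 (1.79 log units; beyond the scatter).

Compound 4, `CN1CCN(CCCN2C(=O)CN(/N=C3\CCOc4ccc(Cl)cc43)C2=O)CC1`, has not been measured in this assay. It differs from compound 3 by chloro in place of methyl on an aromatic carbon. This is the same change, at the same place, as the one from compound 2 to compound 1, so it is seen twice among these compounds. For the measured compounds named here, the difference between the cores of compound 3 and compound 4 on one side and compounds 1 and 2 on the other is the one told above for compound 2 to compound 3.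

Going by the values given here, for compound 4 a step of about the earlier size is expected, a 3.1-fold higher number from compound 3 to compound 4 (0.49 log units; beyond the scatter), because a 3.2-fold higher number from compound 2 to compound 1 (0.51 log units; beyond the scatter) is the only measured example of this change. Compound 4 is thus estimated at 950 nM in this assay. The expected range for compound 4 runs from 300 nM to 3000 nM.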

Compound 4, half-maximal inhibitory concentration: 5.8 nM
Compound 4: the middle estimate sits 160-fold (2.21 log units) above what was measured, outside the stated range (below it).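

In this assay the swap of chloro for methyl on the aromatic carbon made a 52-fold lower number from compound 3 to compound 4 (1.72 log units; beyond the scatter), so the same swap moved the number in opposite directions on the two cores: the same change on two cores in this assay, a 3.2-fold higher number (0.51 log units; beyond the scatter) from compound 2 to compound 1 and a 52-fold lower number (1.72 log units; beyond the scatter) from compound 3 to compound 4, 170-fold (2.23 log units) apart, beyond the scatter of two such steps. Read the other way round, the side-chain change, 4-methylpiperazin-1-yl in place of (piperidin-1-yl)methyl, made an 11000-fold lower number from compound 1 to compound 4 (4.02 log units; beyond the scatter) on the chloro compounds, a far larger step than on the methyl compounds: the same change on two cores in this assay, a 62-fold lower number (1.79 log units; beyond the scatter) from compound 2 to compound 3 and an 11000-fold lower number (4.02 log units; beyond the scatter) from compound 1 to compound 4, 170-fold (2.23 log units) apart, beyond the scatter of two such steps. The two changes therefore do not act independently here, and neither the size nor the direction of the chloro step could be carried from one core to the other, but these four compounds form only one such set and do not show why the steps differ or whether other cores would behave the same way.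

As far as these compounds go, it remains open whether this result belongs to chloro alone or would also appear with fluoro, bromo or methoxy on the same aromatic carbon. Also open, from the compounds shown here alone, is how much of the side-chain step comes from the amine and how much from the chain, which the piperidin-1-yl and 4-methylpiperazin-1-yl groups on chains of equal length could separate.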